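The source may report more compounds than this note shows. Statements on the series, on what has been measured and on what is new or still open speak of the compounds shown alone.

Compound 3 `c1c[nH]c(-c2ccccc2OCC2=NCCN2)c1` gives 1.26 nM in a functional assay for activation of Alpha-1A adrenergic receptor (Homo sapiens), read by calcium flux (on this read-out lower numbers stand for an effect already at smaller amounts and higher numbers for an effect only at larger amounts of compound), the lowest of the two numbers shown. Compound 2 `c1ccc(-c2cnccn2)c(OCC2=NCCN2)c1` gives 2.51 nM in this assay, and the step of a 2.0-fold lower number from compound 2 to compound 3 (0.30 log units; within the scatter) lies within the scatter. Compound 1 `c1ccc(-c2ccncc2)c(OCC2=NCCN2)c1` reaches only the limit < 100000 nM in this assay. The steps a step that the limit leaves unreadable from compound 1 to compound 2 and a step that the limit leaves unreadable from compound 1 to compound 3 are therefore of unreadable size. Compound 4 `c1ccc(-c2nccs2)c(OCC2=NCCN2)c1` differs from compound 3 in one place: 1,3-thiazol-2-yl in place of 1H-pyrrol-2-yl on an aromatic carbon. For the measured compounds named here, the step that bears most directly on this change is a 2.0-fold lower number from compound 2 to compound 3 (0.30 log units; within the scatter), which shows that an exchange of one small aromatic ring for another between compound 2 and compound 3 left the number within the scatter; the two unreadable steps from compound 1 show only that such an exchange can also move the number to the limit. The estimate for compound 4 is 3 nM, within a range from 0.8 nM to 15 nM. This estimate means an expected step of a 2.4-fold higher number from compound 3 to compound 4 (0.38 log units; beyond the scatter) that does not go beyond the scatter.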

Compound 4, half-maximal effective concentration: 2.51 nM
Estimate against measurement, compound 4: 1.2-fold (0.08 log units) above; the measured number falls inside the stated range.
By their numbers in this assay, from the lowest: compounds 3, 2 and 4 (each within the scatter of the next).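

In this assay, 1,3-thiazol-2-yl in place of 1H-pyrrol-2-yl gives a 2.0-fold higher number from compound 3 to compound 4 (0.30 log units; within the scatter), so at this position a ring with a hydrogen-bond donor and no acceptors gives way to one with no donor, two acceptors and a sulfur atom while the number stays within the scatter. The exchange of pyrazin-2-yl for 1,3-thiazol-2-yl gives no change at the digits printed from compound 2 to compound 4 (within the scatter), so three different small aromatic rings now stand within the scatter of one another, and compound 1 is the one that goes against this. Compound 1 stands at a limit, and the steps from it cannot be read: the limit of < 100000 nM in this assay, at which 1 of the 4 values shown sits.

What the compounds shown leave open is why pyridin-4-yl differs from the other rings in this position. They also leave open how the number would respond to a non-aromatic group here, such as an amine, a carboxylic acid or a longer chain.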